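The source may hold more compounds than are shown below. What is called first, only, known or untested is meant among the compounds shown, and "the series" means these compounds.

In an ADME assay on liver for metabolic stability, with Liver microsome (Homo sapiens) as the target, read by LC-MS, using microsomes, with a stated time of 5 h (on this read-out higher numbers stand for fast clearance and lower numbers for slow clearance), compound 1 `OC(c1ncccc1F)C1(c2ccc(Cl)c(Cl)c2)CCC1` gives 833 mL/min/kg and compound 3 `OC(c1ncccn1)C1(c2ccc(OC(F)(F)F)cc2)CCC1` gives 100 mL/min/kg as its reading. Compound 2 `C[C@]1(O)C[C@](c2cccc(OC(F)(F)F)c2)([C@H](O)c2ccccn2)C1` stands at 117 mL/min/kg on the same scale, within the usual scatter of compound 3 and well beyond the scatter from the much higher number of compound 1.

Compound 4 `O[C@H](c1ccccn1)[C@]1(c2cccc(OC(F)(F)F)c2)C[C@H](O)C1` has not been measured yet. It differs from compound 2 in one place, with hydrogen in place of methyl on a saturated ring carbon. Among the measured compounds shown here, no two measured compounds differ in just one place, so the data offer no direct precedent for this change. In this assay no step beyond the scatter is expected, and the direction cannot be called with confidence, although a slightly lower number is taken as the middle guess. The estimated step of a 1.2-fold lower number from compound 2 to compound 4 (0.07 log units; within the scatter) stays within the scatter. For compound 4 the expected clearance is 100 mL/min/kg with an estimated range from 45 mL/min/kg to 220 mL/min/kg on this read-out.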

Compound 4, clearance: 150 mL/min/kg
For compound 4 the middle estimate is 1.5-fold (0.18 log units) below the measured one; low and high end bracket the measured number.
By their numbers in this assay, from the lowest: compounds 3, 2 and 4 (each within the scatter of the next); then compound 1.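

In this assay, hydrogen in place of methyl on a saturated ring carbon of the four-membered ring gives a 1.3-fold higher number from compound 2 to compound 4 (0.11 log units; within the scatter), a step that stays within the usual scatter of repeated measurements. Among the compounds shown here, this is the first comparison here between compounds that differ in one place, and it shows that removing this single carbon does not shift clearance by more than the assay can resolve. No measurement shown here accounts for this result.

Going by these compounds, whether a larger group in this place, such as an ethyl group, an amine or a carboxylic acid, would shift clearance beyond the scatter remains open. A single swap also cannot say whether the same change would behave alike on a different core, such as that of compound 1.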